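Methyl for Chloro on Two Related Cores

The source may report more compounds than this note shows. Statements on the series, on what has been measured and on what is new or still open speak of the compounds shown alone.

Compound 1 `C=C1C[C@]23C[C@@]1(O)CC[C@H]2c1ccc(OS(=O)(=O)c2ccc(C)cc2)c(C)c1[C@@H]3Cn1cc(-c2ccc(Cl)cc2)nn1` and compound 2 `C=C1C[C@]23C[C@@]1(O)CC[C@H]2c1ccc(OS(=O)(=O)c2ccc(C)cc2)c(C)c1[C@@H]3Cn1cc(-c2ccc(C)cc2)nn1` share one core. In a functional assay on MCF7 cells (Homo sapiens) for cytotoxicity, read by MTT assay, with a stated time of 4 days (on this read-out higher numbers stand for weaker inhibition and lower numbers for stronger inhibition), compound 1 gives > 20000 nM, which is a limit of the assay. In this assay compound 2 likewise gives > 20000 nM, again a limit. The change between them, (methyl in place of chloro on an aromatic carbon), therefore yields a step that the two limits leave unreadable from compound 1 to compound 2, since both values sit at the limit of > 20000 nM in this assay, at which 2 of the 3 values shown sit.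

Compound 3 `C=C1C(=O)[C@]23C[C@@]1(O)CC[C@H]2c1ccc(O)c(C)c1[C@@H]3Cn1cc(-c2ccc(Cl)cc2)nn1` has a core whose difference from the core of compound 1 is not broken down here. In this assay compound 3 gives 2470 nM. Compound 4 `C=C1C(=O)[C@]23C[C@@]1(O)CC[C@H]2c1ccc(O)c(C)c1[C@@H]3Cn1cc(-c2ccc(C)cc2)nn1` differs from compound 3 by methyl in place of chloro on an aromatic carbon, the same change as from compound 1 to compound 2.

Because a step that the two limits leave unreadable from compound 1 to compound 2 cannot be read, the expectation rests only on compound 3 at 2470 nM, and the step is expected to be a 1.2-fold higher number from compound 3 to compound 4 (0.08 log units; within the scatter). Compound 4 is thus expected to give about 3000 nM, likely between 1200 nM and 9000 nM.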

Compound 4, half-maximal inhibitory concentration: 370 nM
Beside the measured number, compound 4's estimate is 8.1-fold (0.91 log units) above it; the measured number lies below the stated range.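

In this assay, methyl in place of chloro on an aromatic carbon gives a 6.7-fold lower number from compound 3 to compound 4 (0.82 log units; beyond the scatter), a step beyond the scatter on that one core. Compound 1 and compound 2 each rest at a limit of the assay, so the step between them cannot be read: the limit of > 20000 nM in this assay, at which 2 of the 4 values shown sit. The series therefore shows what the change does on the core of compound 3, but it does not show whether that step, in direction or in size, carries over to the core of compound 1.

The compounds shown leave open how a methoxy group or an amine in place of the chloro would read on the core of compound 3. They also do not separate the individual differences between the two cores.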